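The source may hold more compounds than are shown below. What is called first, only, known or untested is meant among the compounds shown, and "the series" means these compounds.

Cell tolerance of this series is read through an ADME assay on HEK293 cells (Homo sapiens) for cytotoxicity, read by resazurin assay, with a stated time of 72 h; a higher number here means that more compound is tolerated, a lower number that less compound is tolerated. In this assay compound 1 `COc1cccc(CNC(=O)c2nc3ccc(F)c(OCCc4ccccc4)c3c(=O)[nH]2)c1` gives > 20000 nM, which is a limit of the assay and not a number. Compound 2 `O=C(O)c1ccc(CCOc2c(F)ccc3nc(C(=O)NCc4cccc(OCC5CC5)c4)[nH]c(=O)c23)cc1` gives > 20000 nM, again a limit and not a number. Compound 2 thus stands at the limit of > 20000 nM in this assay, at which 2 of the 2 values shown sit, so no exact figure exists for it.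

Compound 3 `CCc1cccc(C(C)NC(=O)c2nc3ccc(F)c(OCCc4ccc(C(=O)O)cc4)c3c(=O)[nH]2)c1` has not yet been measured. It carries 1-(3-ethylphenyl)ethyl in place of 3-(cyclopropylmethoxy)benzyl on an amide-type nitrogen. For the measured compounds named here, no measured pair isolates this change, so the expectation rests only on the limit of compound 2, > 20000 nM. No shift beyond the usual scatter, in either direction, is expected, and the estimated step runs a number no higher from compound 2 to compound 3 (the limit leaves the size open). For compound 3 the expected value is 20000 nM, within an estimated range of 10000 nM to 40000 nM.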

Compound 3, half-maximal cytotoxic concentration: > 20000 nM
Compound 3 gave a limit, no number; the forecaster's own chance of this, stated with the estimate: 80%; the middle value lies on the limit itself.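

Compound 2 and compound 3 each give a limit and not a number, so no step between them can be read: the limit of > 20000 nM in this assay, at which 3 of the 3 values shown sit.

The compounds shown leave open at what concentration cell tolerance ends, and whether 1-(3-ethylphenyl)ethyl and 3-(cyclopropylmethoxy)benzyl differ at all.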